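Methylene lactone and lactam series on L1210 cells

The source may hold more compounds than are shown below. What is called first, only, known or untested is meant among the compounds shown, and "the series" means these compounds.

Measured compounds:
compound 1 `C=C1C(=O)OC(c2ccccc2)C1C` — 4000 nM; 28000 nM (2 entries)
compound 2 `C=C1CC(c2ccccc2)N(C)C1=O` — > 50000 nM

In a functional assay on L1210 cells (Mus musculus) for cytotoxicity, with a stated time of 48 h (on this read-out lower numbers stand for stronger inhibition and higher numbers for weaker inhibition), compound 1 gives 4000 nM; 28000 nM (2 entries), two entries that differ widely (the several entries of compound 1 in this assay, 4000 nM; 28000 nM (2 entries)). Compound 2 reaches only a limit of the assay, > 50000 nM, and no single number (the limit of > 50000 nM in this assay, at which 1 of the 2 values shown sits). Compound 2 therefore stands at the weak end of what is shown, with no step to any other compound measured.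

Compound 3 `C=C1CC(c2ccc(OC)cc2)N(C)C1=O` is not yet measured in this assay. It differs from compound 2 by methoxy in place of hydrogen on an aromatic carbon. Within the data shown here, no measured step of this kind exists, so the size of the change cannot be read from data. The expectation is a step of no size beyond the scatter, in either direction, as a number no higher from compound 2 to compound 3 (the limit leaves the size open). Compound 3 is estimated at 50000 nM, within 15000 nM to 150000 nM, with a fair chance that this assay again reports only a limit.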

Compound 3, half-maximal inhibitory concentration: > 50000 nM
Compound 3 gave a limit, no number (the forecaster's own chance of this, stated with the estimate: 60%); the middle value lies on the limit itself.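

Compound 2 and compound 3 both stand at a limit in this assay, not at a number, so no step can be read for methoxy in place of hydrogen on an aromatic carbon. The compounds shown leave open whether this replacement changes the read-out at all, and in which direction.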